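The source may report more compounds than this note shows. Statements on the series, on what has been measured and on what is new or still open speak of the compounds shown alone.

Measured so far:
Compound 1 `O=C(Nc1ccc(-c2ccccc2)cc1)c1cc([N+](=O)[O-])ccc1Cl` gives 26 10^-6 cm/s
Compound 2 `O=C(Nc1nc(-c2ccc(Cl)cc2)cs1)c1cc([N+](=O)[O-])ccc1Cl` gives 3 10^-6 cm/s

Both values come from an ADME assay for permeability, using PAMPA, at pH 7.4; a lower number here means that the compound crosses the layer more slowly, a higher number that the compound crosses the layer faster. Compound 2, at 3 10^-6 cm/s, holds the lower of the two numbers, and the gap that separates it from compound 1, at 26 10^-6 cm/s, lies beyond the usual scatter. These two compounds differ in more than one place, so their gap cannot be tied to any single change.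

Compound 3 `O=C(Nc1nc(-c2ccc(F)c(F)c2)cs1)c1cc([N+](=O)[O-])ccc1Cl` keeps the rest of compound 2 and changes one group: 3,4-difluorophenyl in place of 4-chlorophenyl on an aromatic carbon. Within the data shown here, no measured pair shows this swap or any other single change, so the data offer no direct guide to its size. The expectation therefore starts from compound 2 at 3 10^-6 cm/s and allows only a modest move. The estimated step is a 1.3-fold higher number from compound 2 to compound 3 (0.12 log units; within the scatter), slightly upward and expected to stay within the scatter. In this assay, the estimate for compound 3 is 4 10^-6 cm/s, with an expected range from 1.5 10^-6 cm/s to 10 10^-6 cm/s.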

Compound 3, apparent permeability: 37 10^-6 cm/s
Beside the measured number, compound 3's estimate is 9.3-fold (0.97 log units) below it; measured number outside the range, above it.
By their numbers in this assay, from the lowest: compound 2; then compounds 1 and 3 (each within the scatter of the next).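

In this assay, among these compounds, putting 3,4-difluorophenyl in place of 4-chlorophenyl, on the aromatic carbon next to the ring nitrogen, gives a 12-fold higher number from compound 2 to compound 3 (1.09 log units; beyond the scatter) and is the first single change that can be read on its own, showing that this position can carry a large move in the read-out. The change is narrow by the counts: one six-membered aromatic ring of carbon only replaces another, with 0 hydrogen-bond donors, 0 hydrogen-bond acceptors and no net charge on either side, while one chlorine leaves and two fluorine enter. No measurement at hand accounts for the size of this step, so the result stands as an observation without an assigned cause.

From the compounds shown here alone, whether a plain phenyl, a fluorophenyl with one fluorine, or a phenyl carrying an amine or a carboxylic acid at this place would give a step of similar size remains open. Going by these compounds, whether the same swap would give a comparable step on another core, such as the core of compound 1, remains open as well.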